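Glucagon receptor series: aryl exchange on compound 1

The source may report more compounds than this note shows. Statements on the series, on what has been measured and on what is new or still open speak of the compounds shown alone.

Three compounds sharing one core have numbers in an assay on CHO cells for displacement of a labelled ligand from Glucagon receptor (Homo sapiens), read by scintillation counting, with a stated time of 60 min; on this read-out higher numbers stand for weaker inhibition and lower numbers for stronger inhibition. Compound 1 `C[C@H](c1ccc(C(=O)NCCC(=O)O)cc1)N1C(=O)C(c2cccc(OC(F)(F)F)c2)=N[C@]12CC[C@@H](C(C)(C)C)CC2` gives 330 nM. Compound 2 `CC1(CC[C@H](c2ccc(C(=O)NCc3nn[nH]n3)cc2)N2C(=O)C(c3cc(Cl)cc(Cl)c3)=N[C@]23CC[C@@H](C(C)(C)C)CC3)CC1` gives 17 nM. Compound 3 `CC(C)(C)[C@H]1CC[C@]2(CC1)N=C(c1ccc(Cl)cc1)C(=O)N2Cc1ccc(C(=O)NCCC(=O)O)cc1` gives 940 nM. Compound 1 therefore sits second highest of the three, with compound 3 nearest at a higher number and compound 2 furthest at a much lower number, both gaps beyond the usual scatter. Compound 2 and compound 3 differ from compound 1 in more than one place, so their values only show the spread the core can reach.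

Compound 4 `C[C@H](c1ccc(C(=O)NCCC(=O)O)cc1)N1C(=O)C(c2cccc(Cl)c2F)=N[C@]12CC[C@@H](C(C)(C)C)CC2` is not yet measured. It differs from compound 1 in one place: 3-chloro-2-fluorophenyl in place of 3-(trifluoromethoxy)phenyl on a carbon with a double bond to nitrogen. For the measured compounds named here, no single-point step of this kind is available among the measured compounds. The aryl on the carbon with a double bond to nitrogen in compound 2 carries two chlorines and accompanies the lowest number, which hints that a halogenated aryl is tolerated here. The expected step of a 1.7-fold lower number from compound 1 to compound 4 (0.22 log units; within the scatter) is modest, toward a lower number, and may fall within the scatter. Compound 4 is estimated at 200 nM, with a range from 60 nM to 700 nM in this assay .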

Compound 4, half-maximal inhibitory concentration: 620 nM
Estimate against measurement, compound 4: 3.1-fold (0.49 log units) below; measured number inside the range.
By their numbers in this assay, from the lowest: compound 2; then compounds 1, 4 and 3 (each within the scatter of the next, the first and the last beyond it).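

In this assay, for the compounds shown here, 3-chloro-2-fluorophenyl in place of 3-(trifluoromethoxy)phenyl gives a 1.9-fold higher number from compound 1 to compound 4 (0.27 log units; within the scatter), the only single-place reading at this carbon with a double bond to nitrogen. At this position, the two aryl groups cannot be told apart on this read-out, even though the entering group has fewer heavy atoms and no hydrogen-bond acceptor. No supporting measurement bears on why the number stays within the scatter.

Going by these compounds, whether a phenyl ring carrying an amine, or a pyridine ring, would be accommodated equally at this position remains open. The separate contributions of the other places in which compound 2 and compound 3 differ cannot be read from these compounds.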